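Exchanging the aryl group on a saturated ring carbon

The compounds below may be only part of what the source reports. "The series", "measured", "known", "first", "only" and "open" are said of these compounds alone.

Measured so far:
compound 1 `COc1cc(N2C(=O)[C@@H](Oc3ccccc3)[C@H]2c2ccc(N=[N+]=[N-])cc2)cc(OC)c1OC`: 23000 nM
compound 2 `COc1cc([C@@H]2[C@H](Oc3ccccc3)C(=O)N2c2cc(OC)c(OC)c(OC)c2)ccc1O`: 32000 nM

Both numbers come from a functional assay on MCF7 cells (Homo sapiens) for antiproliferative activity, read by MTT assay, with stated times of 24 h and 72 h; a higher number here means a weaker inhibitor, a lower number a stronger inhibitor. Going by the values given here, compound 2 stands level with compound 1 on these numbers, since the only measured step is a 1.4-fold higher number from compound 1 to compound 2 (0.14 log units; within the scatter), and the two values cannot be told apart.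

Compound 3 `COc1cc(N2C(=O)[C@@H](Oc3ccccc3)[C@H]2c2cccc(O)c2)cc(OC)c1OC` has not yet been measured. It keeps the shared core and carries 3-hydroxyphenyl in place of 4-hydroxy-3-methoxyphenyl on a saturated ring carbon. Among the compounds with values here, the one measured step bears on this change. It exchanged the group at the same place, 4-azidophenyl for 4-hydroxy-3-methoxyphenyl. That exchange gave a 1.4-fold higher number from compound 1 to compound 2 (0.14 log units; within the scatter), so compound 2 offers no sign that a swap at this place moves the number in this assay. Within the data shown here, no measured pair isolates the exchange made in compound 3, so this evidence is thin, and no step beyond the scatter is expected in either direction. The expected change is small, an estimated 1.2-fold lower number from compound 2 to compound 3 (0.07 log units; within the scatter). Compound 3 is expected at 27000 nM, with an estimated range from 10000 nM to 70000 nM.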

Compound 3, half-maximal inhibitory concentration: 54000 nM
The estimate for compound 3 lay 2.0-fold (0.30 log units) below the measured number; the measured number falls inside the stated range.
By their numbers in this assay, from the lowest: compounds 1, 2 and 3 (each within the scatter of the next, the first and the last beyond it).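

In this assay, replacing 4-hydroxy-3-methoxyphenyl with 3-hydroxyphenyl on the saturated ring carbon gave a 1.7-fold higher number from compound 2 to compound 3 (0.23 log units; within the scatter), so this exchange, like the one before it, cannot be told apart from repeat-measurement noise. Going by these compounds alone, the comparison of 3-hydroxyphenyl with 4-azidophenyl at the same place gave a 2.3-fold higher number from compound 1 to compound 3 (0.37 log units; beyond the scatter), the only step beyond the scatter and the first sign that the aryl group at this position can shift the number, though only modestly. Compound 2 lies within the scatter of both other compounds, so only compound 1 and compound 3 can be ordered, and no measurement at hand offers an explanation for the difference between them.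

The compounds shown leave open whether a plain phenyl, or an aryl group carrying an amine or a carboxylic acid, would move the number further at this place, and in which direction. The phenoxy group and the rest of the shared core are the same in all three compounds, so they also leave open how the number would respond to an exchange anywhere else.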